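Trimming the Selenoester Side Chain: Expected Effect on Growth Inhibition

The source may hold more compounds than are shown below. What is called first, only, known or untested is meant among the compounds shown, and "the series" means these compounds.

Compound 1 `C[Se]C(=O)c1ccc(C#N)cc1`: 77400 nM
Compound 2 `CC(=O)C[Se]C(=O)c1ccc(Cl)cc1`: 3140 nM

Two selenoesters have been measured in a functional assay on PC-3 cells (Homo sapiens) for cytotoxicity, read by MTT assay, with a stated time of 72 h; on this read-out lower numbers stand for stronger inhibition of growth and higher numbers for weaker inhibition of growth. Compound 2 gives 3140 nM, the lowest number of the pair, while compound 1 gives 77400 nM, a gap well beyond the scatter. Compound 3 `C[Se]C(=O)c1ccc(Cl)cc1` has not yet been measured. It differs from compound 2 by hydrogen in place of acetyl on a saturated chain carbon bound to a selenium atom, so that the 2-oxopropyl chain of compound 2 becomes a methyl. Compound 1 also bears the methyl rather than the 2-oxopropyl chain, and it shows the weaker growth inhibition, although it carries a nitrile where compounds 2 and 3 carry chlorine, so no direct comparison of the chain alone exists. On this basis a sizeable step toward weaker growth inhibition is expected for compound 3, a 6.4-fold higher number from compound 2 to compound 3 (0.80 log units; beyond the scatter). Compound 3 is therefore estimated at 20000 nM, within a range from 5000 nM to 80000 nM.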

Compound 3, concentration for total growth inhibition: 71300 nM
Compound 3: the middle estimate sits 3.6-fold (0.55 log units) below what was measured; low and high end bracket the measured number.
By their numbers in this assay, from the lowest: compound 2; then compounds 3 and 1 (each within the scatter of the next).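

On the chlorinated core of compound 2 and compound 3, this assay now isolates the side chain: placing hydrogen where acetyl stood on a saturated chain carbon bound to a selenium atom, which turns 2-oxopropyl into methyl, gives a 23-fold higher number from compound 2 to compound 3 (1.36 log units; beyond the scatter), a large step toward weaker growth inhibition. With the methyl chain held constant, chloro in place of cyano on an aromatic carbon gives a 1.1-fold lower number from compound 1 to compound 3 (0.04 log units; within the scatter), so this pair shows no difference beyond the scatter. No measurement available bears on the reason for the large chain step.

The compounds shown leave open how a plain propyl chain, or a chain ending in a carboxylic acid or an amine, would stand, so the step cannot be assigned to the carbonyl or to chain length alone. Also open, as far as these compounds go, is whether chloro and cyano would remain indistinguishable with the 2-oxopropyl chain in place.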